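Substituent on the saturated ring nitrogen, fused-core series

This account rests on a few compounds, and the source may have more. Where it says the series, first, only, none or still open, it means among the compounds named here.

Measured so far:
compound 1 `CN1CCN(c2ccc(Nc3ncc4nc(Nc5ccc(F)cc5)n([C@@H]5CCN(C(=O)OC(C)(C)C)C5)c4n3)cc2)CC1` — 27 nM
compound 2 `CN1CCN(c2ccc(Nc3ncc4nc(Nc5ccc(F)cc5)n([C@H]5CCN(C(=O)CO)C5)c4n3)cc2)CC1` — 380 nM
compound 3 `CN1CCN(c2ccc(Nc3ncc4nc(Nc5ccc(F)cc5)n([C@@H]5CCCN(C(=O)CO)C5)c4n3)cc2)CC1` — 66 nM

In a functional assay on HCC827 cells (Homo sapiens) for antiproliferative activity, read by MTT assay, with a stated time of 72 h (a lower number here means a stronger inhibitor, a higher number a weaker inhibitor), compound 3 gives 66 nM, the second highest of the three numbers. Compound 1 gives 27 nM and compound 2 gives 380 nM. The steps among them all exceed the scatter: a 2.4-fold higher number from compound 1 to compound 3 (0.39 log units; beyond the scatter), a 5.8-fold lower number from compound 2 to compound 3 (0.76 log units; beyond the scatter) and a 14-fold higher number from compound 1 to compound 2 (1.15 log units; beyond the scatter). What sits on the saturated ring nitrogen, and the size of that ring, both move the number clearly.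

Compound 4 `CN1CCN(c2ccc(Nc3ncc4nc(Nc5ccc(F)cc5)n([C@H]5CCCNC5)c4n3)cc2)CC1` differs from compound 3 in one place: piperidin-3-yl in place of 1-((hydroxymethyl)carbonyl)piperidin-3-yl on an aromatic nitrogen. For the measured compounds named here, no measured step removes the group from that nitrogen entirely, so direction cannot be read off directly. The two steps that change the group, a 14-fold higher number from compound 1 to compound 2 (1.15 log units; beyond the scatter) and a 2.4-fold higher number from compound 1 to compound 3 (0.39 log units; beyond the scatter), both show that altering it shifts the number, in each case upward from compound 1. A modest upward shift is therefore expected for compound 4, with wide uncertainty: a 1.8-fold higher number from compound 3 to compound 4 (0.26 log units; within the scatter). Compound 4 is estimated at 120 nM, within 35 nM to 450 nM.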

Compound 4, half-maximal inhibitory concentration: 38 nM
Compound 4: the middle estimate sits 3.2-fold (0.50 log units) above what was measured, within the range that was stated.
By their numbers in this assay, from the lowest: compounds 1, 4 and 3 (each within the scatter of the next, the first and the last beyond it); then compound 2.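

In this assay the piperidine ring nitrogen does not need its substituent: replacing 1-((hydroxymethyl)carbonyl)piperidin-3-yl with piperidin-3-yl gives a 1.7-fold lower number from compound 3 to compound 4 (0.24 log units; within the scatter) as the step. The free piperidin-3-yl also stays level with 1-(tert-butoxycarbonyl)pyrrolidin-3-yl, with a 1.4-fold higher number from compound 1 to compound 4 (0.15 log units; within the scatter) as the step in this series. The 1-((hydroxymethyl)carbonyl)pyrrolidin-3-yl group is the clear outlier among the four, with a 10-fold lower number from compound 2 to compound 4 (1.00 log units; beyond the scatter) as the step to the free piperidine. Nothing on hand explains these steps.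

Going by these compounds, the number for a free pyrrolidin-3-yl remains open, so the effect of ring size without a substituent cannot yet be separated from the effect of the group. On these data alone, it also remains open whether a methyl, an acetyl or a longer aminoalkyl chain on the piperidine nitrogen would keep the number in this range.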